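The source may report more compounds than this note shows. Statements on the series, on what has been measured and on what is new or still open speak of the compounds shown alone.

Compound 1, `CC1CCCc2c1[nH]c(=O)c(C#N)c2-c1cccn1C`, in a functional assay on SN12C cells (Homo sapiens) for inhibition, read by sulforhodamine B assay, with a stated time of 48 h (on this read-out lower numbers stand for stronger inhibition of growth and higher numbers for weaker inhibition of growth), gives > 100000 nM, which is a limit of the assay and not a number.
Compound 2, `Cn1cccc1-c1cc(-c2cccs2)nc(N)c1C#N`, in this assay gives > 100000 nM, again a limit of the assay rather than a measured number.

Compound 2 therefore stands nowhere in particular on the numbers shown: both values in this assay are limits, and the limit of > 100000 nM in this assay, at which 2 of the 2 values shown sit, holds for every value in view, so no ordering between compound 1 and compound 2 can be drawn from them.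

Compound 3, `Cn1cccc1-c1cc(-c2ccccc2)nc(N)c1C#N`, is the next compound to be measured in this assay. Its difference from compound 2 is phenyl in place of thiophen-2-yl on an aromatic carbon. Among the measured compounds shown here, no step between measured compounds is available to gauge what this change does. Since compound 2 itself reached only a limit, the step from compound 2 to compound 3 is expected to be none beyond the scatter, shown as a number no higher from compound 2 to compound 3 (the limit leaves the size open), with the reading for compound 3 most likely remaining a limit as well. Compound 3 is estimated to give 100000 nM in this assay, expected to fall between 30000 nM and 300000 nM.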

Compound 3, concentration for 50% growth inhibition: > 100000 nM
Compound 3 ended at the assay's limit; the forecaster's own chance of this, stated with the estimate: 85%; the middle value sits exactly at the limit.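

No step can be read from compound 2 to compound 3, phenyl in place of thiophen-2-yl on an aromatic carbon, because both readings are limits of the assay and not numbers: the limit of > 100000 nM in this assay, at which 3 of the 3 values shown sit.

The compounds shown leave open how compound 1, compound 2 and compound 3 compare in this assay, and which change would bring a measurable value.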